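The source may hold more compounds than are shown below. What is called first, only, known or untested is meant among the compounds shown, and "the series" means these compounds.

In a functional assay on HCT-8 cells (Homo sapiens) for cytotoxicity, read by MTT assay, with a stated time of 24 h (on this read-out lower numbers stand for stronger inhibition and higher numbers for weaker inhibition), compound 1 (`CCOC(=O)c1cn(CCCc2ccccc2)c2cc(Cl)ccc2c1=O`) gives 17000 nM. Compound 2 (`CCOC(=O)c1cn(C)c2cc(Cl)ccc2c1=O`) gives > 50000 nM, which is a limit. Compound 3 (`CCCCn1cc(C(=O)OCC)c(=O)c2ccc(Cl)cc21`) gives > 50000 nM, also a limit, so it stands at the limit of > 50000 nM in this assay, at which 2 of the 3 values shown sit. Compound 4 (`CCOC(=O)c1cn(CC)c2cc(Cl)ccc2c1=O`) differs from compound 3 by hydrogen in place of ethyl on a saturated chain carbon, two bonds along the chain from an aromatic nitrogen, the change from butyl to ethyl. The steps of an at least 2.9-fold higher number from compound 1 to compound 2 (0.46 log units; beyond the scatter) and an at least 2.9-fold higher number from compound 1 to compound 3 (0.46 log units; beyond the scatter) both remove the phenyl-bearing chain, and neither bears directly on a change between plain alkyl chains. The closest evidence is a step that the two limits leave unreadable from compound 2 to compound 3, which spans methyl to butyl. No step beyond the scatter is therefore expected in this assay, and a further limit reading is likely. The expected step is a step that the limit leaves unreadable from compound 3 to compound 4. Compound 4 is estimated at 60000 nM, within an expected range of 30000 nM to 100000 nM.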

Compound 4, half-maximal inhibitory concentration: > 50000 nM
Compound 4: only a limit was reported; the forecaster's own chance of this, stated with the estimate: 85%; the middle value does not contradict the limit.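

In this assay compound 4 gives > 50000 nM, which is a limit. Shortening butyl to ethyl therefore brings no reading as a number, and the phenyl-ended chain again stands apart, with an at least 2.9-fold higher number from compound 1 to compound 4 (0.46 log units; beyond the scatter). The steps among compound 2, compound 3 and compound 4 cannot be read, so methyl, ethyl and butyl all end at the same limit: the limit of > 50000 nM in this assay, at which 3 of the 4 values shown sit.

From the compounds shown here alone, it remains open whether the lower number of compound 1 depends on the phenyl ring or on chain length. A longer plain alkyl chain such as octyl, or a chain ending in an amine, would bear on this.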